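Dropping the chloro from compound 2: what to expect

The source may report more compounds than this note shows. Statements on the series, on what has been measured and on what is new or still open speak of the compounds shown alone.

Measured so far:
Compound 1 `O=c1cc(CSC(=S)N2CCCCC2)oc2ccccc12` gives 12000 nM in a functional assay on HEp-2 cells (Homo sapiens) for antiproliferative activity, read by MTT assay, with a stated time of 72 h; on this read-out lower numbers stand for stronger inhibition and higher numbers for weaker inhibition.
Compound 2 `O=c1cc(CSC(=S)N2CCOCC2)oc2cc(Cl)ccc12` gives 20600 nM in this assay.

Both compounds share a core that carries a dithiocarbamate tail; compound 1 has a piperidine ring there, compound 2 a morpholine ring and a chloro on the aromatic part of the core. Of the two numbers in this assay, compound 2 has the higher one, but its gap to compound 1 lies within the scatter, so the two cannot be ranked.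

Compound 3 `O=c1cc(CSC(=S)N2CCOCC2)oc2ccccc12` is compound 2 with hydrogen in place of chloro on an aromatic carbon, the chloro leaving from its site on a six-membered aromatic ring of carbon only, part of a fused system of two rings. Among the compounds with values here, no measured pair shows this change, so a step no larger than the scatter is expected in this assay, in no set direction. For compound 3 the estimate in this assay is 16000 nM, with a range from 7000 nM to 40000 nM, meaning an expected step of a 1.3-fold lower number from compound 2 to compound 3 (0.11 log units; within the scatter).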

Compound 3, half-maximal inhibitory concentration: > 25000 nM
Compound 3 was reported as a limit; the forecaster's own chance of this, stated with the estimate: 10%; middle value at least 1.5-fold (0.19 log units) away from the limit.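

Compound 3 is reported only as a limit of the assay, not as a number, in this assay: the limit of > 25000 nM in this assay, at which 1 of the 3 values shown sits. Removing the chloro from the aromatic carbon gives an at least 1.2-fold higher number from compound 2 to compound 3 (0.08 log units; that floor lies within the scatter), so this floor alone does not establish a real change at this position, although the true step could be larger. Within the data shown here, the swap of piperidin-1-yl for morpholin-4-yl on the thiocarbonyl carbon gives an at least 2.0-fold higher number from compound 1 to compound 3 (0.31 log units; beyond the scatter), the first step here that clears the scatter, and it shows weaker inhibition with the morpholine ring, with the size of the loss still unbounded.

The compounds shown leave open how a fluoro or methoxy group on that aromatic carbon would compare with chloro. They also leave open whether a pyrrolidine ring or a diethylamino group on the thiocarbonyl carbon would match piperidine.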